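This account rests on a few compounds, and the source may have more. Where it says the series, first, only, none or still open, it means among the compounds named here.

Compound 1 `CCCOC1=C(CCC)C(=O)/C(=C(O)/C=C/c2ccccc2)C(=O)C1(CCC)CCC` gives 1.6 uM in a functional assay on MCF7 cells (Homo sapiens) for antiproliferative activity, read by sulforhodamine B assay, with a stated time of 3 days; on this read-out higher numbers stand for an effect only at larger amounts of compound and lower numbers for an effect already at smaller amounts. Going by the values given here, of the two compounds measured so far, compound 1 has the lowest number; the nearest is compound 2 `COC1=C(CC=C(C)C)C(=O)/C(=C(O)/C=C/c2ccccc2)C(=O)C1(CC=C(C)C)CC=C(C)C`, which gives 8.2 uM in this assay, a gap beyond the usual scatter. Compound 2 differs from compound 1 in several places at once, so no single step can be read from that pair.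

Compound 3 `CCCC1=C(OCC)C(CCC)(CCC)C(=O)/C(=C(O)\C=C\c2ccccc2)C1=O` has not yet been measured. It differs from compound 1 in one place only: hydrogen in place of methyl on a saturated chain carbon, two bonds along the chain from an oxygen on an unsaturated carbon. Among the compounds with values here, no measured pair shows a change of this kind, so there is nothing in the data to point to a shift in either direction. The expected step is therefore small, a 1.3-fold higher number from compound 1 to compound 3 (0.10 log units; within the scatter), and not beyond the scatter in either direction. Compound 3 is estimated to give about 2 uM in this assay, with a likely range from 0.8 uM to 5 uM.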

Compound 3, concentration for half-maximal effect: 2.6 uM
Estimate against measurement, compound 3: 1.3-fold (0.11 log units) below, within the range that was stated.
By their numbers in this assay, from the lowest: compounds 1 and 3 (each within the scatter of the next); then compound 2.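

In this assay, going by these compounds alone, the change from propoxy to ethoxy provides the first comparison in this set that differs in one place only: a 1.6-fold higher number from compound 1 to compound 3 (0.21 log units; within the scatter). Removing this one methyl, on a saturated chain carbon, two bonds along the chain from an oxygen on an unsaturated carbon, therefore produces no difference that this read-out can separate from ordinary repeat variation. No measurement available here bears on why the two compounds cannot be told apart.

The compounds shown leave open whether a longer chain such as hexyloxy, or an amine or a carboxylic acid at the end of this chain, would also leave the number within the scatter. They also leave open whether shortening one of the propyl chains to ethyl would give a similarly small step.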